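Hydrazone series: furan-2-yl in place of 2-hydroxyphenyl

The source may report more compounds than this note shows. Statements on the series, on what has been measured and on what is new or still open speak of the compounds shown alone.

Compound 2 `O=C(N/N=C/c1ccccc1O)c1cc(-c2ccccc2)nn1Cc1ccc(Cl)nc1`: in a functional assay on A549 cells (Homo sapiens) for cytotoxicity, read by MTT assay, with a stated time of 96 h (on this read-out lower numbers stand for stronger inhibition and higher numbers for weaker inhibition), compound 2 gives 5830 nM.
Compound 1 `O=C(N/N=C/c1ccco1)c1cc(-c2ccccc2)nn1Cc1ccccc1`: in this assay compound 1 gives "not determined" (no result reported).
Compound 3 `COc1ccc(/C=N/NC(=O)c2cc(-c3ccccc3)nn2Cc2ccc(Cl)nc2)cc1`: in this assay compound 3 gives "not determined" (no result reported).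

Among the compounds with values here, compound 2 stands alone on the numbers: it carries the only value in this assay, and compounds 1 and 3 carry no number at all, so compound 2 cannot be placed as stronger or weaker than anything else in the set.

Compound 4 `O=C(N/N=C/c1ccco1)c1cc(-c2ccccc2)nn1Cc1ccc(Cl)nc1` is the next entry. It differs from compound 2 in one place: furan-2-yl in place of 2-hydroxyphenyl on a carbon with a double bond to nitrogen, with the shared core and the chloropyridinylmethyl group kept as they are. Within the data shown here, no step between two measured compounds is available, so the data give no direction for this change. The expected step is therefore small, estimated as a 1.5-fold higher number from compound 2 to compound 4 (0.16 log units; within the scatter). The estimate for compound 4 in this assay is 8500 nM, with a range from 2500 nM to 30000 nM. Compound 1, the other furan-2-yl hydrazone in the set, has no reported number, so there is a real chance that compound 4 also returns only a limit rather than a value.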

Compound 4, half-maximal inhibitory concentration: 26100 nM
Compound 4: the middle estimate sits 3.1-fold (0.49 log units) below what was measured; low and high end bracket the measured number.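

In this assay, the group on the carbon with a double bond to nitrogen proves able to move the read-out: furan-2-yl in place of 2-hydroxyphenyl gives a 4.5-fold higher number from compound 2 to compound 4 (0.65 log units; beyond the scatter) and lies beyond the usual scatter, which gives the series its first measured direction. Within this one pair, with the shared core and the chloropyridinylmethyl group unchanged, 2-hydroxyphenyl goes with the lower number and therefore the stronger inhibition, and furan-2-yl goes with the higher number. No supporting measurement is available to explain the difference between the two groups.

The exchange alters ring size and removes the hydrogen-bond donor in a single step, so this pair cannot separate the two differences; an unsubstituted phenyl group or a thiophene ring at the same place would be needed to tell them apart. Steps involving compounds 1 and 3 cannot be read, which leaves open whether the preference for 2-hydroxyphenyl over furan-2-yl carries over to other groups on the shared core.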